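Compound 3 to compound 4: chloro in place of fluoro

The source may report more compounds than this note shows. Statements on the series, on what has been measured and on what is new or still open speak of the compounds shown alone.

Values in a functional assay on OVCAR-3 cells (Homo sapiens) for antiproliferative activity, read by MTT assay, with a stated time of 24 h; a higher number here means a weaker inhibitor, a lower number a stronger inhibitor:
- compound 1 `O=c1[nH]cc(S(=O)(=O)Nc2ccccc2-c2cn(-c3ccccc3)nn2)c(=O)[nH]1`: 6650 nM
- compound 2 `O=c1[nH]cc(S(=O)(=O)Nc2ccccc2-c2cn(-c3cccc(F)c3)nn2)c(=O)[nH]1`: > 20000 nM (a limit)
- compound 3 `O=c1[nH]cc(S(=O)(=O)Nc2ccccc2-c2cn(-c3ccc(F)cc3)nn2)c(=O)[nH]1`: > 20000 nM (a limit)

In this assay compound 3 gives > 20000 nM, which is a limit and not a number. Among the measured compounds shown here, the series so far shows (the limit of > 20000 nM in this assay, at which 2 of the 3 values shown sit).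

Compound 4 `O=c1[nH]cc(S(=O)(=O)Nc2ccccc2-c2cn(-c3ccc(Cl)cc3)nn2)c(=O)[nH]1` carries chloro in place of fluoro on an aromatic carbon.

For the measured compounds named here, no measured step makes this exchange. The closest are the two changes of fluoro in place of hydrogen on an aromatic carbon, an at least 3.0-fold higher number from compound 1 to compound 2 (0.47 log units; beyond the scatter) and an at least 3.0-fold higher number from compound 1 to compound 3 (0.47 log units; beyond the scatter). Both lie beyond the scatter, while a step that the two limits leave unreadable from compound 2 to compound 3 cannot be sized. With an at least 3.0-fold higher number from compound 1 to compound 3 (0.47 log units; beyond the scatter) as the guide, compound 4 is expected to stay on the weak side of compound 1, near the limit, and no direction can be expected relative to compound 3.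

For compound 4 the estimated value is 16000 nM, with an expected range of 5000 nM to 45000 nM.

The expected change is an at least 1.2-fold lower number from compound 3 to compound 4 (0.09 log units; that floor lies within the scatter).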

Compound 4, half-maximal inhibitory concentration: 1750 nM
Beside the measured number, compound 4's estimate is 9.1-fold (0.96 log units) above it, outside the stated range (below it).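

In this assay this position does not respond to halogens alike: chloro in place of hydrogen gives a 3.8-fold lower number from compound 1 to compound 4 (0.58 log units; beyond the scatter), the first substitution in the series to lower the number rather than raise it. The choice of halogen sets the direction at this carbon, with an at least 11-fold lower number from compound 3 to compound 4 (1.05 log units; beyond the scatter) for chloro in place of fluoro and an at least 11-fold lower number from compound 2 to compound 4 (1.05 log units; beyond the scatter) for 4-chlorophenyl in place of 3-fluorophenyl. Compound 2 and compound 3 are each read only as a limit, not a number: the limit of > 20000 nM in this assay, at which 2 of the 4 values shown sit.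

The compounds shown leave open whether the lower number is particular to chloro or extends to bromo, methyl or methoxy at this carbon, and whether chloro would do the same at the ring carbon that carries fluoro in compound 2. The step between compound 2 and compound 3 cannot be read, so the two fluoro placements remain unordered.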